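Tetrazole for Triazole on a Second Core: Distribution Volume

The compounds below may be only part of what the source reports. "The series", "measured", "known", "first", "only" and "open" are said of these compounds alone.

Measured so far:
compound 1 `Cc1cc(Cl)ccc1-c1cccc(COc2ccc([C@H](CC(=O)O)c3ncnn3C)cc2)c1`: 3.5 L/kg
compound 2 `Cc1cc(Cl)ccc1-c1cccc(COc2ccc([C@H](CC(=O)O)c3nnnn3C)cc2)c1`: 14.3 L/kg
compound 3 `Cc1nc(-c2ccc(C(F)(F)F)cc2)sc1COc1ccc([C@H](CC(=O)O)c2ncnn2C)cc1`: 1.5 L/kg

In an ADME assay on the whole organism for pharmacokinetics, with Rattus norvegicus as the target (a lower number here means that more of the compound stays in the plasma, a higher number that more of the compound sits outside the plasma), compound 1 gives 3.5 L/kg and compound 2 gives 14.3 L/kg. For the measured compounds named here, the single change between them, (1-methyl-1H-tetrazol-5-yl in place of 1-methyl-1H-1,2,4-triazol-5-yl on a saturated chain carbon bound to an aromatic carbon and a saturated chain carbon), produced a 4.1-fold higher number from compound 1 to compound 2 (0.61 log units; beyond the scatter). Compound 3, built on a different core, gives 1.5 L/kg in this assay, the lowest of the three numbers; the difference between its core and the core of compound 1 is not broken down here.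

Compound 4 `Cc1nc(-c2ccc(C(F)(F)F)cc2)sc1COc1ccc([C@H](CC(=O)O)c2nnnn2C)cc1` has not yet been measured in this assay. It carries the same change relative to compound 3, (1-methyl-1H-tetrazol-5-yl in place of 1-methyl-1H-1,2,4-triazol-5-yl on a saturated chain carbon bound to an aromatic carbon and a saturated chain carbon), at the same place as in the pair of compound 1 and compound 2. Going by the values given here, the only precedent, a 4.1-fold higher number from compound 1 to compound 2 (0.61 log units; beyond the scatter), points upward, and compound 3 starting from 1.5 L/kg leaves room for a comparable rise. Compound 4 is therefore expected to show a 3.7-fold higher number from compound 3 to compound 4 (0.56 log units; beyond the scatter) in this assay. One precedent on one core is a thin basis, so the expectation is held loosely. Compound 4 is estimated at 5.5 L/kg, with a plausible range from 2.5 L/kg to 12 L/kg.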

Compound 4, volume of distribution at steady state: 3.2 L/kg
Beside the measured number, compound 4's estimate is 1.7-fold (0.24 log units) above it; measured number inside the range.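

In this assay, 1-methyl-1H-tetrazol-5-yl in place of 1-methyl-1H-1,2,4-triazol-5-yl on the second core gives a 2.1-fold higher number from compound 3 to compound 4 (0.33 log units; beyond the scatter), so the change raises the number on both cores shown. The two steps differ by no more than repeated measurements would allow, so the data give no sign that the core alters the size of the effect: the same change on two cores in this assay, a 4.1-fold higher number (0.61 log units; beyond the scatter) from compound 1 to compound 2 and a 2.1-fold higher number (0.33 log units; beyond the scatter) from compound 3 to compound 4, 1.9-fold (0.28 log units) apart, within the scatter of two such steps. This is a shared direction on two cores only; it does not show that the step would keep its size or direction on a further core, and it does not explain why the number rises.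

The compounds shown leave open whether the same step holds when an amide stands in place of the carboxylic acid, or when a longer chain carries the acid. They also leave open what an ethyl group in place of the methyl on the tetrazole or triazole ring would do to the step.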